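From 1H-imidazol-1-yl to phenylsulfanyl on a thiocarbonyl carbon

This account rests on a few compounds, and the source may have more. Where it says the series, first, only, none or still open, it means among the compounds named here.

Measured in an ADME assay on HepG2 cells (Homo sapiens) for cytotoxicity, read by CellTiter-Glo, with a stated time of 72 h; on this read-out higher numbers stand for an effect only at larger amounts of compound and lower numbers for an effect already at smaller amounts:
Compound 1 `CC1=C2CC(C)(C)/C=C/[C@H](O)/C(C)=C\C3=C[C@H](C)C[C@]3(O2)C1=O`: 18700 nM
Compound 2 `CC1=C2CC(C)(C)/C=C/[C@H](OC(=S)n3ccnc3)/C(C)=C\C3=C[C@H](C)C[C@]3(O2)C1=O`: 26000 nM

Compound 2 stands level with compound 1, since their values lie within the usual scatter of each other. Compound 3 `CC1=C2CC(C)(C)/C=C/[C@H](OC(=S)Sc3ccccc3)/C(C)=C\C3=C[C@H](C)C[C@]3(O2)C1=O` has not yet been measured. It keeps the thiocarbonyl carbon of compound 2 but changes what that carbon carries: phenylsulfanyl in place of 1H-imidazol-1-yl on a thiocarbonyl carbon. In words, phenylsulfanyl takes the place of 1H-imidazol-1-yl.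

Within the data shown here, only one measured step bears on this: a 1.4-fold higher number from compound 1 to compound 2 (0.14 log units; within the scatter). That step replaced a hydrogen atom with a whole group, so it is a loose guide to swapping one group for another. Among the measured compounds shown here, no measured compound carries phenylsulfanyl. With so little evidence, no shift beyond the scatter is expected in this assay, in either direction. The expected result is a 1.2-fold lower number from compound 2 to compound 3 (0.07 log units; within the scatter). For compound 3 the estimated value is 22000 nM, with an expected range of 9000 nM to 50000 nM.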

Compound 3, half-maximal effective concentration: 26000 nM
Beside the measured number, compound 3's estimate is 1.2-fold (0.07 log units) below it, within the range that was stated.
By their numbers in this assay, from the lowest: compounds 1, 2 and 3 (each within the scatter of the next).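

In this assay, exchanging the nitrogen-containing ring for a carbon-only aromatic ring gives no change at the digits printed from compound 2 to compound 3 (within the scatter) so 1H-imidazol-1-yl and phenylsulfanyl read alike on this thiocarbonyl carbon. Set against the parent alcohol, the new group gives a 1.4-fold higher number from compound 1 to compound 3 (0.14 log units; within the scatter) so a second, differently built group on this oxygen also stays level with compound 1. Nothing measured here offers an explanation for this level reading.

Both groups shown reach the oxygen through a thiocarbonyl carbon, so it remains open whether a group without that carbon, such as a simple acetyl or a methyl ether, would read the same. On these data alone, it is also open whether a group carrying an amine or a carboxylic acid would stay level with these three compounds.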